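The source may hold more compounds than are shown below. What is called first, only, known or untested is meant among the compounds shown, and "the series" means these compounds.

Compound 2 `COc1cc2nccc(Oc3ccc4c(NC(=O)c5cc(Cl)ccn5)nn(C)c4c3)c2cc1OC` stands among three compounds examined in a functional assay on HUVEC cells (Homo sapiens) for inhibition, with stated times of 2 h and 72 h; on this read-out lower numbers stand for stronger inhibition and higher numbers for weaker inhibition. In this assay compound 2 gives > 1000 nM, which is a limit of the assay and not a number. Compound 1 `COc1cc2nccc(Oc3ccc4c(NC(=O)C5CC5)nn(C)c4c3)c2cc1OC` in this assay gives > 1000 nM, likewise a limit. Compound 3 `COc1cc2nccc(Oc3ccc4c(NC(=O)c5cccc(C)c5)nn(C)c4c3)c2cc1OC` in this assay gives > 1000 nM, again a limit. All three thus share (the limit of > 1000 nM in this assay, at which 3 of the 3 values shown sit). Accordingly the step that the two limits leave unreadable from compound 1 to compound 2 and the step that the two limits leave unreadable from compound 2 to compound 3 offer no readable size, and nothing measured bears readably on the change to compound 4 `COc1cc2nccc(Oc3ccc4c(NC(=O)Nc5ccc(C)cc5)nn(C)c4c3)c2cc1OC`, which differs from compound 2 by (4-methylphenyl)amino in place of 4-chloropyridin-2-yl on a carbonyl carbon. Compound 4 is therefore expected to give about 2000 nM, within 300 nM to 20000 nM. The step that the limit leaves unreadable from compound 2 to compound 4 is thus an estimate that the limit may again leave unreadable.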

Compound 4, half-maximal inhibitory concentration: > 1000 nM
Compound 4: a limit, no number; the forecaster's own chance of this, stated with the estimate: 70%; the middle value does not contradict the limit.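

Compound 4, like compounds 1, 2 and 3, gives only a limit and no number, so none of its steps to those compounds can be read: the limit of > 1000 nM in this assay, at which 4 of the 4 values shown sit.

The compounds shown leave open whether the group on the carbonyl carbon makes any difference in this assay.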